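The compounds below may be only part of what the source reports. "The series", "measured", "known", "first", "only" and "open" are said of these compounds alone.

Measured compounds in the series:

compound 1 `Cn1nc2c(=O)n(CC3(O)CCN(Cc4ccc(-c5ccco5)cc4Cl)CC3)cnc2c1-c1ccc(CO)cc1` — 42.5 nM
compound 2 `Cn1nc2c(=O)n(CC3(O)CCN(Cc4ccc(-c5cccs5)cc4Cl)CC3)cnc2c1-c1ccc(CN)cc1` — 38.6 nM
compound 3 `Cc1ccc(-c2ccc(CN3CCC(O)(Cn4cnc5c(-c6ccc(CN)cc6)n(C)nc5c4=O)CC3)c(Cl)c2)s1` — 101 nM

All three numbers come from an assay on isolated protein for inhibition of ubiquitin carboxyl-terminal hydrolase 7 (Homo sapiens), with stated times of 30 min and 2 h; a lower number here means a stronger inhibitor, a higher number a weaker inhibitor. Compound 1 stands second highest of the three; its nearest neighbour is compound 2, whose number lies within the scatter of it, and its furthest is compound 3, which gives a number beyond the scatter above it. Among the compounds with values here, the one single-point step in the set, a 2.6-fold higher number from compound 2 to compound 3 (0.42 log units; beyond the scatter), places methyl in place of hydrogen on an aromatic carbon and weakens inhibition modestly.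

Compound 4 `Cn1nc2c(=O)n(CC3(O)CCN(Cc4ccc(-c5ccco5)cc4Cl)CC3)cnc2c1-c1ccc(C(=N)N)cc1` is not yet measured. Against compound 1 the change is a group of 3 heavy atoms (1 carbon, 2 nitrogen; no ring) in place of a group of 2 heavy atoms (1 carbon, 1 oxygen; no ring), on an aromatic carbon, sitting on the aromatic carbon para to a large group. Within the data shown here, no measured step touches this position on its own: compounds 1 and 2 differ there, but they differ at a second place as well, and their two values sit within the scatter of each other. That pair suggests that exchanging the hydroxymethyl for another small polar group does not move the number much, so for compound 4 the step of a 1.2-fold lower number from compound 1 to compound 4 (0.08 log units; within the scatter) is expected to fall within the scatter. Compound 4 is therefore estimated at 35 nM, with a range of 12 nM to 100 nM.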

Compound 4, half-maximal inhibitory concentration: 87.5 nM
Compound 4: middle estimate off by 2.5-fold (0.40 log units), on the low side; the range from low to high includes it.
By their numbers in this assay, from the lowest: compounds 2 and 1 (each within the scatter of the next); then compounds 4 and 3 (each within the scatter of the next).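

In this assay, within the data shown here, there is a 2.1-fold higher number from compound 1 to compound 4 (0.31 log units; beyond the scatter) and this is the first step that changes only the group on the aromatic carbon para to a large group; the number at this position does respond to the exchange of hydroxymethyl for the group of 3 heavy atoms (1 carbon, 2 nitrogen; no ring), though only modestly. Compound 1 and compound 2 differ here and at a second place as well, so their closeness does not show that small polar groups are interchangeable at this carbon, and the new step now stands against that reading. Nothing at hand explains why the number moves with this exchange.

Still open, going by these compounds, is how the aminomethyl group of compound 2 would compare with hydroxymethyl when the rest of compound 1 is held fixed. Also open, on these data alone, is how a carboxylic acid, a primary amide or a longer chain such as 2-hydroxyethyl would read on this same aromatic carbon, and thus whether the position tolerates anything beyond the small groups seen so far.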